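Clearance notes: aryl-sulfonyl series, compound 4 projection

This account rests on a few compounds, and the source may have more. Where it says the series, first, only, none or still open, it means among the compounds named here.

Measured:
- compound 1 `O=S(=O)(c1ccc(F)c(F)c1)c1cnc2c(F)cccc2c1-c1ccc(Cl)cc1`: 0.28 mL/min
- compound 2 `Cc1ccc(S(=O)(=O)c2cnc3c(F)cccc3c2-c2ccc(Cl)cc2)cc1F`: 2.2 mL/min
- compound 3 `COc1ccc(S(=O)(=O)c2cnc3c(F)cccc3c2-c2ccc(Cl)cc2)cc1`: 1.05 mL/min

In an ADME assay on microsomes from liver (Homo sapiens) for metabolic stability, tested at 2.5 uM (a lower number here means slower removal, a higher number faster removal of the compound), compound 1 gives the lowest of the three numbers; compound 3 sits nearer to it and compound 2 furthest, with a 3.8-fold higher number from compound 1 to compound 3 (0.57 log units; beyond the scatter) and a 7.9-fold higher number from compound 1 to compound 2 (0.90 log units; beyond the scatter) both beyond the scatter. Compound 4 `COc1ccc(-c2c(S(=O)(=O)c3ccc(F)c(F)c3)cnc3c(F)cccc23)cc1` differs from compound 1 by methoxy in place of chloro on an aromatic carbon. Among the compounds with values here, no measured step alters this position: the steps from compound 1 to compound 2 and to compound 3 change only the group on the sulfonyl sulfur. Within the data shown here, the one step that brings in a methoxy, a 3.8-fold higher number from compound 1 to compound 3 (0.57 log units; beyond the scatter), sits at a different place, so it gives at most a loose guide. An upward step of roughly that size or smaller is expected in this assay, written as a 2.5-fold higher number from compound 1 to compound 4 (0.40 log units; beyond the scatter). For compound 4 the expected value is 0.7 mL/min, within 0.25 mL/min to 2 mL/min.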

Compound 4, intrinsic clearance in a liver preparation (reported as CLH), per the amount of preparation that the assay uses: 2.12 mL/min
The estimate for compound 4 lay 3.0-fold (0.48 log units) below the measured number; the whole stated range lies below it.
By their numbers in this assay, from the lowest: compound 1; then compound 3; then compounds 4 and 2 (each within the scatter of the next).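

Within the data shown here, the aryl position on the shared core, untouched by the earlier steps, clearly affects the result: in this assay, 4-methoxyphenyl in place of 4-chlorophenyl gives a 7.6-fold higher number from compound 1 to compound 4 (0.88 log units; beyond the scatter). This step is similar in size to the largest sulfonyl-side change, a 7.9-fold higher number from compound 1 to compound 2 (0.90 log units; beyond the scatter), so clearance responds to changes on both sides of the molecule. Nothing available explains the rise.

Open, from the compounds shown here alone, is how this position responds to other groups, such as a nitrile, an amine or a carboxylic acid. Also open, going by these compounds, is whether methoxy in place of chloro gives a similar step when the group on the sulfonyl sulfur is not 3,4-difluorophenyl.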